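Chalcone series: bromo for iodo on the hydroxy-bearing ring

The compounds below may be only part of what the source reports. "The series", "measured", "known", "first", "only" and "open" are said of these compounds alone.

Two chalcones have been measured in a functional assay on PC-3 cells (Homo sapiens) for antiproliferative activity, with a stated time of 48 h; a higher number here means a weaker inhibitor, a lower number a stronger inhibitor. Compound 1 `O=C(/C=C/c1ccccc1)c1ccc(OCc2ccccc2)cc1O` gives 34700 nM in this assay. Compound 2 `COc1ccc(C(=O)/C=C/c2ccccc2)c(O)c1I` gives 34000 nM in this assay. On these two numbers compound 2 stands beside compound 1: the gap between them is within the scatter, so the two compounds cannot be told apart in this assay.

Compound 3 `COc1ccc(C(=O)/C=C/c2ccccc2)c(O)c1Br` has not been measured in this assay. It differs from compound 2 in one place (bromo in place of iodo on an aromatic carbon). Among the compounds with values here, no measured pair in the set shows such a halogen swap, so nothing in the data points to a step beyond the scatter in either direction. The expectation is therefore a step from compound 2 to compound 3 of about a 1.0-fold higher number from compound 2 to compound 3 (0.01 log units; within the scatter), with the estimate for compound 3 in this assay put at 35000 nM, within a range from 15000 nM to 80000 nM.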

Compound 3, half-maximal inhibitory concentration: 47800 nM
Beside the measured number, compound 3's estimate is 1.4-fold (0.14 log units) below it, within the range that was stated.
By their numbers in this assay, from the lowest: compounds 2, 1 and 3 (each within the scatter of the next).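

In this assay, within the data shown here, the first direct halogen swap on this aromatic carbon, ortho to a hydroxy group and ortho to a methoxy group, gives a 1.4-fold higher number from compound 2 to compound 3 (0.15 log units; within the scatter), and that step lies within the scatter. At this position, then, bromo and iodo cannot be told apart in this read-out, so the change of halogen gives no measurable handle on antiproliferative activity. Nothing on hand explains this result or links it to any property of either halogen.

Open, on these data alone, is whether this carbon needs a halogen at all, or whether hydrogen, an amine or a nitrile in its place would move the number beyond the scatter. Also open, as far as these compounds go, is whether a longer chain such as ethoxy in place of the methoxy group would change how this position responds.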